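This account rests on a few compounds, and the source may have more. Where it says the series, first, only, none or still open, it means among the compounds named here.

Measured so far in a toxicity assay on NIH3T3 cells (Mus musculus) for cytotoxicity, read by resazurin assay (on this read-out lower numbers stand for an effect already at smaller amounts and higher numbers for an effect only at larger amounts of compound), all three values being limits:
- Compound 1 `c1ccc(-c2ccc(Cn3cncc3CNc3ccc(-c4ccccc4)c(-c4ccccc4)c3)cc2)cc1`: > 10000 nM
- Compound 2 `CNC(=O)c1ccc(NCc2cncn2Cc2ccc(-c3ccccc3)cc2)cc1-c1ccccc1`: > 1000 nM
- Compound 3 `c1ccc(-c2ccc(Cn3cncc3CNc3ccc(-c4ccc[nH]4)c(-c4ccccc4)c3)cc2)cc1`: > 10000 nM

Compound 3 stands at a limit, > 10000 nM, and no number is known for it. Compound 4 `COc1ccc(NCc2cncn2Cc2ccc(-c3ccccc3)cc2)cc1-c1ccccc1` differs from it by methoxy in place of 1H-pyrrol-2-yl on an aromatic carbon.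

Three measured steps exchange the group at this same place: a step that the two limits leave unreadable from compound 1 to compound 2, a step that the two limits leave unreadable from compound 1 to compound 3 and a step that the two limits leave unreadable from compound 2 to compound 3. None has a readable size, so they offer no direction for the new change. Among the measured compounds shown here, every compound so far reaches only a limit in this assay, so no step beyond the scatter is expected, and the assay will probably report a limit again. The estimate for compound 4 is 10000 nM, with an expected range from 2500 nM to 30000 nM. This estimate means an expected a number no higher from compound 3 to compound 4 (the limit leaves the size open).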

Compound 4, half-maximal effective concentration: > 1000 nM
Compound 4: a limit, no number; the forecaster's own chance of this, stated with the estimate: 80%; the middle value is on the limit's open side.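

Compound 4 gives only a limit in this assay, > 1000 nM, so its steps from compound 1, compound 2 and compound 3 cannot be read. The compounds shown leave open whether exchanging the group at this place changes the cytotoxic effect at all, and in which direction.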